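The compounds below may be only part of what the source reports. "The series", "measured", "known", "first", "only" and "open" are said of these compounds alone.

Series so far, measured in a functional assay on A-431 cells (Homo sapiens), read by propidium iodide staining, with a stated time of 24 h; on this read-out higher numbers stand for an effect only at larger amounts of compound and lower numbers for an effect already at smaller amounts:
- compound 1 `FC(F)(F)c1cccc(-c2nnc(-c3cccnc3NCc3ccncc3)[nH]2)c1`: compound 1 gives > 10000 nM, a limit
- compound 2 `c1ccc(-c2nnc(Nc3ccc4c(c3)OCCO4)[nH]2)c(NCc2ccncc2)c1`: compound 2 gives > 10000 nM, a limit
- compound 3 `c1cncc(CNc2ccccc2-c2nnc(Nc3ccc4c(c3)OCCO4)[nH]2)c1`: compound 3 gives > 10000 nM, a limit

Compound 3 therefore has no number, only a limit of this assay. The same holds for the whole series, which shows (the limit of > 10000 nM in this assay, at which 3 of the 3 values shown sit).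

The next compound is compound 4 `c1ccc(-c2nnc(Nc3ccc4c(c3)OCCO4)[nH]2)c(NCc2ccc3[nH]ncc3c2)c1`. It keeps the shared core of compound 3 and carries 1H-indazol-5-yl in place of pyridin-3-yl on a saturated chain carbon bound to a nitrogen on an aromatic ring.

For the measured compounds named here, only one measured step bears on this place, and it is a step that the two limits leave unreadable from compound 2 to compound 3. That step swapped pyridin-4-yl for pyridin-3-yl, and it gives no size to carry over. The larger group entering here has not been tested on this core, so a move towards smaller amounts cannot be excluded. The more likely outcome remains a result at or close to the limit. The expected change is an at least 1.2-fold lower number from compound 3 to compound 4 (0.09 log units; that floor lies within the scatter), and it is expected to be small or unreadable. The estimate for compound 4 is 8000 nM, with an expected range of 1500 nM to 30000 nM.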

Compound 4, half-maximal effective concentration: > 10000 nM
Compound 4: no number, only a limit; the forecaster's own chance of this, stated with the estimate: 65%; at least 1.2-fold (0.09 log units) between middle value and limit.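

Compound 4 gives only a limit, as do compound 2 and compound 3, so no step among these three can be read in this assay. The whole series stays at one limit: the limit of > 10000 nM in this assay, at which 4 of the 4 values shown sit.

The compounds shown leave open whether any group on a saturated chain carbon bound to a nitrogen on an aromatic ring gives a readable number in this assay.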